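Working notes on a small amide series and one analogue

This account rests on a few compounds, and the source may have more. Where it says the series, first, only, none or still open, it means among the compounds named here.

Measured so far:
compound 1 `COc1cccc(NC(=O)CSc2nc(Nc3ccccc3)c3ccccc3n2)c1` — 11600 nM
compound 2 `O=C(CSc1nc(Nc2ccccc2)c2ccccc2n1)Nc1ccc(F)cc1` — 9560 nM
compound 3 `C=CC(=O)Nc1cccc(NC(=O)CSc2nc(Nc3cccc(OC)c3)c3ccccc3n2)c1` — 34900 nM

In a functional assay on PC-3 cells (Homo sapiens) for inhibition, read by MTT assay, with a stated time of 72 h (a higher number here means a weaker inhibitor, a lower number a stronger inhibitor), compound 1 gives 11600 nM and compound 2 gives 9560 nM; the two values lie within the scatter of one another. Compound 3 gives 34900 nM in this assay, and its steps to compound 1 and to compound 2 are both beyond the scatter, so it is the weakest of the three.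

Within the data shown here, the only single-point step that has been measured is a 1.2-fold lower number from compound 1 to compound 2 (0.08 log units; within the scatter), where the change is 4-fluorophenyl in place of 3-methoxyphenyl on an amide-type nitrogen. Compound 3 and compound 1 differ in more than one place; the difference between the two cores is not broken down here.

Compound 4 `C=CC(=O)Nc1cccc(NC(=O)CSc2nc(Nc3ccc(F)cc3)c3ccccc3n2)c1` is the one still to be measured in this assay. Its relation to compound 3 is 4-fluorophenyl in place of 3-methoxyphenyl on a nitrogen on an aromatic ring. The change is the same kind as that from compound 1 to compound 2, not the same: there the place was an amide-type nitrogen whose other neighbour is a carbonyl carbon, here it is a nitrogen on an aromatic ring whose other neighbours are aromatic carbon. Given that the only measured instance, a 1.2-fold lower number from compound 1 to compound 2 (0.08 log units; within the scatter), stayed within the scatter, the step expected here is a 1.2-fold lower number from compound 3 to compound 4 (0.08 log units; within the scatter), of similar small size, though the different place leaves the direction open. Compound 4 is therefore estimated at 29000 nM in this assay. The expected range for compound 4 runs from 12000 nM to 70000 nM.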

Compound 4, half-maximal inhibitory concentration: 8240 nM
Compound 4: middle estimate off by 3.5-fold (0.55 log units), on the high side; measured number below the stated range.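

In this assay, 4-fluorophenyl in place of 3-methoxyphenyl on a nitrogen on an aromatic ring gives a 4.2-fold lower number from compound 3 to compound 4 (0.63 log units; beyond the scatter), and the earlier instance of this change does not match it: the same change on two cores in this assay, a 1.2-fold lower number (0.08 log units; within the scatter) from compound 1 to compound 2 and a 4.2-fold lower number (0.63 log units; beyond the scatter) from compound 3 to compound 4, 3.5-fold (0.54 log units) apart, beyond the scatter of two such steps The size of the step therefore did not carry from one core to the other within this series, and the near-silent step between compound 1 and compound 2 gave no reliable guide to the step between compound 3 and compound 4. This does not show what sets the two steps apart, since the cores differ and the change also sits at a different place, on an amide-type nitrogen in one pair and on a nitrogen on an aromatic ring in the other, and two pairs support no general rule for the series.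

The compounds shown leave open whether the lower number for compound 4 comes from the arrival of the fluorine or from the departure of the methoxy group, since the two changes are made together in this pair. They also leave open how an amine or a carboxylic acid in the place of either group would behave on the core of compound 3.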